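Same atoms, undrawn configuration: estimating compound 4

The source may report more compounds than this note shows. Statements on the series, on what has been measured and on what is new or still open speak of the compounds shown alone.

Compound 1 `C/C1=C\CC(C)(C)/C=C/C(=O)[C@@H](CO)CCC1`: 70600 nM
Compound 2 `C/C1=C\CC(C)(C)/C=C/C(=O)[C@H](CO)CCC1`: 33100 nM
Compound 3 `CO[C@@H]1CC/C(C)=C/CC(C)(C)/C=C/C(=O)[C@H]1CO`: 27200 nM

All three values come from a functional assay on RAW264.7 cells (Mus musculus) for inhibition, read by Griess assay, with stated times of 2 h and 24 h; on this read-out higher numbers stand for weaker inhibition and lower numbers for stronger inhibition. Compound 3, at 27200 nM, agrees with compound 2 within the usual scatter. The remaining comparison shows a clearer gap: a 2.6-fold lower number from compound 1 to compound 3 (0.41 log units; beyond the scatter).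

The next compound to be tested is compound 4 `COC1CC/C(C)=C/CC(C)(C)/C=C/C(=O)C1CO`. Its difference from compound 3 is this: the two compounds have the same atoms and bonds; at least one stereo element is drawn with a configuration in one of them and without one in the other: 2 of 4 stereo elements differ; a stereocentre at a saturated ring carbon is drawn R in compound 3 and without a configuration in compound 4; a stereocentre at a saturated ring carbon is drawn S in compound 3 and without a configuration in compound 4. No group is added or removed, so the methoxy step above offers little guidance. The relevant measurement is a 2.1-fold lower number from compound 1 to compound 2 (0.33 log units; beyond the scatter), a modest step that can be traced to the fact that compounds 1 and 2 differ only in the configuration as drawn. That shows configuration can matter in this assay, but only modestly, and the drawing of compound 4 does not show which configuration is present. A small rise in the number is therefore expected, though not one beyond the scatter. The expected change is a 1.2-fold higher number from compound 3 to compound 4 (0.07 log units; within the scatter). Compound 4 is estimated at 32000 nM, with an expected range of 16000 nM to 65000 nM.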

Compound 4, half-maximal inhibitory concentration: 18100 nM
Beside the measured number, compound 4's estimate is 1.8-fold (0.25 log units) above it, and the stated range covers the measured number.
By their numbers in this assay, from the lowest: compounds 4, 3 and 2 (each within the scatter of the next); then compound 1.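

In this assay the result is a 1.5-fold lower number from compound 3 to compound 4 (0.18 log units; within the scatter), so dropping the drawn configuration at the two saturated ring carbons does not separate these compounds. The earlier configuration step, a 2.1-fold lower number from compound 1 to compound 2 (0.33 log units; beyond the scatter), compared two drawn forms and lay beyond the scatter, whereas this one does not set one known configuration against another. That limits what it can show about configuration at these carbons, and the only structural difference available to interpret is this: the fact that one of compounds 3 and 4 is drawn with a defined configuration and the other without, at the place where they differ

The compounds shown leave open what configuration compound 4 actually has and how each other arrangement at these two carbons would read on its own. They also leave open whether an ethoxy group or an amine in place of the methoxy would change the number.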